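Swapping in 4-methoxycyclohexyl: an expected half-life for compound 4

The source may hold more compounds than are shown below. What is called first, only, known or untested is meant among the compounds shown, and "the series" means these compounds.

Of the compounds shown here, three on a shared core have been measured so far in an ADME assay on microsomes from liver (Homo sapiens) for metabolic stability, read by LC-MS, using NADPH, with a stated time of 10 min, tested at 10 uM (a higher number here means that the compound lasts longer, a lower number that the compound disappears faster), and they set the frame here. Compound 3 (`Nc1ncnc2c1c(Oc1cc(C(F)(F)F)ccn1)nn2[C@H]1C[C@H](F)C1`) gives 2.03 h in that test. Compound 2 (`Nc1ncnc2c1c(Oc1cc(C(F)(F)F)ccn1)nn2CC1CC1`) gives 1.87 h there, so the two stand level (a 1.1-fold higher number from compound 2 to compound 3 (0.04 log units; within the scatter)). Compound 1 (`Nc1ncnc2c1c(Oc1cc(C(F)(F)F)ccn1)nn2[C@@H]1CCCC[C@H]1O`) reports only a limit of the assay, > 2.41 h as its entry.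

Compound 4 (`CO[C@H]1CC[C@H](n2nc(Oc3cc(C(F)(F)F)ccn3)c3c(N)ncnc32)CC1`) carries 4-methoxycyclohexyl in place of 3-fluorocyclobutyl on an aromatic nitrogen. The steps bearing on this change swap groups at that same nitrogen (an at least 1.2-fold lower number from compound 1 to compound 2 (0.11 log units; that floor lies within the scatter); an at least 1.1-fold lower number from compound 1 to compound 3 (0.07 log units; that floor lies within the scatter)), and both floors lie within the scatter. Compound 1 also has a cyclohexyl group, but its limit gives no exact size. Within the data shown here, no measured step therefore points to a real shift. The estimated step (a 1.0-fold higher number from compound 3 to compound 4 (0.01 log units; within the scatter)) is expected to stay within the scatter. In this assay the estimate for compound 4 is 2.1 h as the expected value, with 1.2 h to 3.3 h as the expected range.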

Compound 4, half-life: > 2.41 h
Compound 4 ended at the assay's limit; the forecaster's own chance of this, stated with the estimate: 30%; at least 1.1-fold (0.05 log units) between middle value and limit.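

At this aromatic nitrogen, 4-methoxycyclohexyl is the second six-membered carbon ring to leave its compound at a limit of the assay in this assay: the limit of > 2.41 h in this assay, at which 2 of the 4 values shown sit. The steps to compound 4 from the two smaller groups therefore give floors only, with an at least 1.1-fold higher number from compound 3 to compound 4 (0.07 log units; that floor lies within the scatter) and an at least 1.2-fold higher number from compound 2 to compound 4 (0.11 log units; that floor lies within the scatter), so neither shows a real gain, yet neither fixes how large the true step is. The step from compound 1 to compound 4 cannot be read, so the methoxy group and the hydroxyl group cannot be ranked against each other.

On these data alone, how long compound 1 and compound 4 actually last in this test remains open. Also open, as far as these compounds go, is whether a plain cyclohexyl or an aminocyclohexyl group at this nitrogen would reach the same limit.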